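Compound 4: a swapped aryl group on a limit-bound core

The source may report more compounds than this note shows. Statements on the series, on what has been measured and on what is new or still open speak of the compounds shown alone.

Compound 1 `COc1cccc(N2C(=O)COc3ccc(-c4cnc(Cl)c(NS(=O)(=O)c5ccc(F)cc5)c4)cc32)c1`: > 40000 nM (a limit)
Compound 2 `COc1ccc(N2C(=O)COc3ccc(-c4ccc(O)cc4)cc32)cc1`: 26100 nM
Compound 3 `COc1cccc(N2C(=O)COc3ccc(-c4cnc(OC)c(NS(=O)(=O)c5ccc(F)cc5)c4)cc32)c1`: > 40000 nM (a limit)

In a functional assay on HCT-116 cells (Homo sapiens) for antiproliferative activity, read by MTT assay, with a stated time of 72 h (on this read-out lower numbers stand for stronger inhibition and higher numbers for weaker inhibition), compound 1 gives > 40000 nM, which is a limit and not a number. Compound 3 gives > 40000 nM, which is also a limit. Together they make up (the limit of > 40000 nM in this assay, at which 2 of the 3 values shown sit). Compound 2 is the only one of the three with a number, at 26100 nM.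

Compound 4 `Cc1ccc(N2C(=O)COc3ccc(-c4cnc(Cl)c(NS(=O)(=O)c5ccc(F)cc5)c4)cc32)cc1` keeps the core of compound 1 and differs from it in one place: 4-methylphenyl in place of 3-methoxyphenyl on an amide-type nitrogen in a ring. In words, 4-methylphenyl stands in place of 3-methoxyphenyl on an amide-type nitrogen in a ring.

Only one measured step links two of these compounds, and it concerns a different place: a step that the two limits leave unreadable from compound 1 to compound 3, with methoxy in place of chloro on an aromatic carbon. For the measured compounds named here, it offers no size to carry over, and no measured step covers the new change. No step beyond the scatter can therefore be expected in either direction, and compound 4 is expected to remain close to the limit in this assay. The step expected on this basis is a number no higher from compound 1 to compound 4 (the limit leaves the size open). For compound 4 the estimated value is 40000 nM, with an expected range from 18000 nM to 80000 nM.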

Compound 4, half-maximal inhibitory concentration: 34300 nM
Compound 4: middle estimate off by 1.2-fold (0.07 log units), on the high side, and the stated range covers the measured number.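

In this assay, 4-methylphenyl in place of 3-methoxyphenyl on an amide-type nitrogen in a ring gives an at least 1.1-fold lower number from compound 1 to compound 4 (0.06 log units; that floor lies within the scatter), the first step at this position among the compounds shown and the first in the series with a readable floor. With this swap the core of compound 1 yields a number rather than a limit, but the floor of the step lies within the scatter, and the data show no gain in activity that can be claimed for the change. How large the step really is stays open because compound 1 sits at a limit: the limit of > 40000 nM in this assay, at which 2 of the 4 values shown sit.

Going by these compounds, whether an amine or a carboxylic acid carried on the aryl group, or a longer chain in its place on the amide-type nitrogen, would shift the number well away from this level remains open. Also open, on these data alone, is whether methoxy in place of chloro on an aromatic carbon would give a readable step when 4-methylphenyl sits on that nitrogen.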